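Methoxy for dimethylamino on the shared core

The compounds below may be only part of what the source reports. "The series", "measured", "known", "first", "only" and "open" are said of these compounds alone.

Compound 1 `Cc1ccc(/C=C2\CCC/C(=C\c3ccc([N+](=O)[O-])cc3)C2=O)cc1` gives 8160 nM in a functional assay on L1210 cells (Mus musculus) for cytotoxicity, with a stated time of 48 h; a higher number here means a weaker inhibitor, a lower number a stronger inhibitor. For compound 2 `CN(C)c1ccc(/C=C2\CCC/C(=C\c3ccc([N+](=O)[O-])cc3)C2=O)cc1` this assay reports only a limit, > 500000 nM. The step of an at least 61-fold higher number from compound 1 to compound 2 (1.78 log units; beyond the scatter) is therefore large, and compound 2 stands at the weak end of the two numbers shown, sitting at the limit of > 500000 nM in this assay, at which 1 of the 2 values shown sits, rather than at a measured value. Compound 3 `COc1ccc(/C=C2\CCC/C(=C\c3ccc([N+](=O)[O-])cc3)C2=O)cc1` is unmeasured; it differs from compound 2 by methoxy in place of dimethylamino on an aromatic carbon. Going by the values given here, only one measured step bears on this change: an at least 61-fold higher number from compound 1 to compound 2 (1.78 log units; beyond the scatter) moved toward weaker inhibition when dimethylamino replaced methyl. Compound 3 carries neither of those groups, so for compound 3 the step expected in this assay is an at least 20-fold lower number from compound 2 to compound 3 (1.30 log units; beyond the scatter), toward a lower number, though the limit on compound 2 leaves the size uncertain. The value of compound 3 in this assay is estimated at 25000 nM, with a range from 5000 nM to 500000 nM.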

Compound 3, half-maximal inhibitory concentration: 240000 nM
Compound 3: the middle estimate sits 9.6-fold (0.98 log units) below what was measured; the measured number falls inside the stated range.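

In this assay, methoxy gives a measured value at this position on the aromatic ring, and the step of a 29-fold higher number from compound 1 to compound 3 (1.47 log units; beyond the scatter) is large, so the move toward weaker inhibition seen with dimethylamino in place of methyl is not confined to dimethylamino. Replacing dimethylamino with methoxy recovers only part of that ground, with the step of an at least 2.0-fold lower number from compound 2 to compound 3 (0.31 log units; beyond the scatter) fixing a minimum and leaving its full size unknown. Compound 2 remains a limit: the limit of > 500000 nM in this assay, at which 1 of the 3 values shown sits.

On these data alone, how a chlorine or a hydroxyl at this position would read remains open, as does whether an ethyl or longer alkyl chain in place of methyl would stay close to compound 1. The nitro-bearing side is the same in all the compounds shown, so whether this ranking holds with another group there is also open.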